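From compound 2 to its acetoxy analogue

The compounds below may be only part of what the source reports. "The series", "measured", "known", "first", "only" and "open" are said of these compounds alone.

Measured so far:
compound 1 `COc1ccccc1OCC1SCCN1C(=O)CSC` gives 21 mg/kg
compound 2 `COc1ccccc1OCC1SCCN1C(=O)C[S+](C)[O-]` gives 10 mg/kg
compound 3 `COc1ccccc1OCC1N(C(=O)CS(C)(=O)=O)CC[S+]1[O-]` gives 28 mg/kg

In a functional assay on the whole organism (trachea) for inhibition, with Cavia porcellus as the target (a lower number here means that less compound is needed, a higher number that more compound is needed for the effect), compound 2 has the lowest of the three numbers, at 10 mg/kg. Compound 4 `COc1ccccc1OCC1SCCN1C(=O)COC(C)=O` is not yet measured. Among the compounds with values here, it changes the same place as the one single-place step available: a group of 4 heavy atoms (2 carbon, 2 oxygen; no ring) in place of a group of 3 heavy atoms (1 carbon, 1 oxygen, 1 sulfur; no ring), on a saturated chain carbon bound to a carbonyl carbon. That measured step is modest: a 2.1-fold lower number from compound 1 to compound 2 (0.32 log units; beyond the scatter). Compound 3 differs from compound 2 in more than one place, so it offers no clean comparison. Within the data shown here, with one modest step as the only guide, a step of similar or smaller size is expected, more likely towards a higher number. The expected change is a 1.5-fold higher number from compound 2 to compound 4 (0.18 log units; within the scatter). For compound 4 the estimated value is 15 mg/kg, with an expected range from 7 mg/kg to 32 mg/kg.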

Compound 4, dose for half-maximal effect: 25 mg/kg
Compound 4: middle estimate off by 1.7-fold (0.22 log units), on the low side; low and high end bracket the measured number.
By their numbers in this assay, from the lowest: compound 2; then compounds 1, 4 and 3 (each within the scatter of the next).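

In this assay, acetoxy in place of the group of 3 heavy atoms in compound 2 gives a 2.5-fold higher number from compound 2 to compound 4 (0.40 log units; beyond the scatter), so the gain seen with that group does not carry over to every group with oxygen in it. Acetoxy also gives no gain over methylsulfanyl, with a 1.2-fold higher number from compound 1 to compound 4 (0.08 log units; within the scatter). Within the data shown here, of these three groups on the saturated chain carbon bound to a carbonyl carbon, only the one in compound 2 stands apart.

Going by these compounds, how an amine or a carboxylic acid would behave at this place remains open. Nothing available explains why the group in compound 2 stands apart.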